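The source may report more compounds than this note shows. Statements on the series, on what has been measured and on what is new or still open speak of the compounds shown alone.

Values from a functional assay on SH-SY5Y cells (Homo sapiens) for antiproliferative activity, read by MTT assay, with a stated time of 72 h (on this read-out higher numbers stand for weaker inhibition and lower numbers for stronger inhibition), follow
- compound 1 `COc1cc2c(Nc3ccc(C#N)cc3)ncnc2cc1OCCCN1CCCC1` gives 8080 nM
- compound 2 `COc1cc2c(Nc3ccc(C#N)cc3)ncnc2cc1OCCCN1CCC(CO)CC1` gives 21600 nM
- compound 3 `COc1cc2c(Nc3ccc(C#N)cc3)ncnc2cc1OCCCN1CCN(c2ccncc2)CC1` gives 31600 nM

Compound 1 holds the lowest of these three numbers. Compound 4 `COc1cc2c(Nc3ccccc3C#N)ncnc2cc1OCCCN1CCCC1` departs from it in one place 2-cyanophenyl in place of 4-cyanophenyl on a nitrogen on an aromatic ring with 2-cyanophenyl in place of 4-cyanophenyl on a nitrogen on an aromatic ring. Among the measured compounds shown here, no measured step touches that place. The measured steps change only the group on the saturated chain: a 2.7-fold higher number from compound 1 to compound 2 (0.43 log units; beyond the scatter) and a 3.9-fold higher number from compound 1 to compound 3 (0.59 log units; beyond the scatter) are modest, while a 1.5-fold higher number from compound 2 to compound 3 (0.17 log units; within the scatter) stays within the scatter. They bear on the change only loosely and give no firm direction. For the measured compounds named here, with compound 1 at 8080 nM as the lowest number so far, a modest rise in this assay is expected, tentatively, as a 1.4-fold higher number from compound 1 to compound 4 (0.13 log units; within the scatter) in the estimate. For compound 4 the estimated value is 11000 nM with an expected range from 4000 nM to 30000 nM as its limits.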

Compound 4, half-maximal inhibitory concentration: 28900 nM
The estimate for compound 4 lay 2.6-fold (0.42 log units) below the measured number, within the range that was stated.
By their numbers in this assay, from the lowest: compound 1; then compounds 2, 4 and 3 (each within the scatter of the next).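

In this assay, 2-cyanophenyl in place of 4-cyanophenyl on the nitrogen gives a modest rise (a 3.6-fold higher number from compound 1 to compound 4 (0.55 log units; beyond the scatter)). Among the compounds shown here, this shows that the number responds at this position, which the earlier compounds left untouched, even though the two groups have the same atoms joined differently. No evidence is available to explain the rise. The compounds shown leave open how 3-cyanophenyl, or an amine or carboxylic acid in place of the nitrile, would read here. They also leave open whether the step would recur with the chain groups of compound 2 and compound 3.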